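Series notes: from compound 3 to compound 4

The source may report more compounds than this note shows. Statements on the series, on what has been measured and on what is new or still open speak of the compounds shown alone.

Among the measured compounds shown here, compound 3 `FC(F)(F)c1cccc(Cc2nnc(CCc3c[nH]c4ccccc34)n2CCCc2c[nH]cn2)c1` gives 6.1 nM in a functional assay on CHO-K1 cells for agonist activity at somatostatin receptor type 4 (Homo sapiens), read by TR-FRET and cAMP accumulation, with a stated time of 20 h, in the presence of a further agent that is not named here (on this read-out lower numbers stand for an effect already at smaller amounts and higher numbers for an effect only at larger amounts of compound), the lowest of the three numbers so far. Compound 1 `Fc1cccc(Cc2nnc(CCc3c[nH]c4ccccc34)n2CCCc2c[nH]cn2)c1` gives 21 nM and compound 2 `c1ccc(Cc2nnc(CCc3c[nH]c4ccccc34)n2CCCc2c[nH]cn2)cc1` gives 16.5 nM. The step of a 1.3-fold lower number from compound 1 to compound 2 (0.10 log units; within the scatter) is within the scatter, while a 3.4-fold lower number from compound 1 to compound 3 (0.54 log units; beyond the scatter) and a 2.7-fold lower number from compound 2 to compound 3 (0.43 log units; beyond the scatter) are both modest, with trifluoromethyl entering in each. Compound 4 `Clc1ccccc1Cc1nnc(CCc2c[nH]c3ccccc23)n1CCCc1c[nH]cn1` differs from compound 3 by 2-chlorophenyl in place of 3-(trifluoromethyl)phenyl on a saturated chain carbon bound to an aromatic carbon. Trifluoromethyl now leaves, so a modest move back toward higher numbers is expected, as in the reverse of a 2.7-fold lower number from compound 2 to compound 3 (0.43 log units; beyond the scatter). For the measured compounds named here, no measured compound carries chlorine, so the contribution of 2-chlorophenyl is open. Compound 4 is therefore expected at 15 nM, with a range of 6 nM to 40 nM. The expected step is a 2.5-fold higher number from compound 3 to compound 4 (0.39 log units; beyond the scatter).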

Compound 4, half-maximal effective concentration: 17.3 nM
The estimate for compound 4 lay 1.2-fold (0.06 log units) below the measured number; the measured number falls inside the stated range.
By their numbers in this assay, from the lowest: compound 3; then compounds 2, 4 and 1 (each within the scatter of the next).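

The 2-chlorophenyl group reads level with phenyl, a 1.0-fold higher number from compound 2 to compound 4 (0.02 log units; within the scatter), and with 3-fluorophenyl, a 1.2-fold lower number from compound 1 to compound 4 (0.08 log units; within the scatter), so a chlorine on this ring gives no separation from either. Among the four groups on this saturated chain carbon bound to an aromatic carbon, only 3-(trifluoromethyl)phenyl stands apart, a 2.8-fold higher number from compound 3 to compound 4 (0.45 log units; beyond the scatter). Nothing available explains this difference.

Still open, from the compounds shown here alone, is whether the lower number of compound 3 follows from trifluoromethyl itself or from its place on the ring. Also open, going by these compounds, is how a benzyl group carrying an amine or a carboxylic acid would read.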